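Ethoxyphenyl in Place of Fluorophenyl on the Shared Core

This account rests on a few compounds, and the source may have more. Where it says the series, first, only, none or still open, it means among the compounds named here.

Working notes on the series. Three compounds share a core that carries a trimethoxyphenyl group and a pendant aryl ring, and differ only in that ring. Compound 1 `COc1cc(-n2cnc3ccc(-c4cccc(F)c4)cc32)cc(OC)c1OC` in a functional assay on MCF7 cells (Homo sapiens) for antiproliferative activity, read by MTT assay, with a stated time of 72 h (a lower number here means a stronger inhibitor, a higher number a weaker inhibitor), gives 2350 nM. Compound 2 `COc1cc(-n2cnc3ccc(-c4cc(F)ccc4F)cc32)cc(OC)c1OC` gives 6420 nM, and compound 3 `COc1cc(-n2cnc3ccc(-c4cccc(O)c4)cc32)cc(OC)c1OC` gives 350 nM. Compound 1 thus stands second highest of the three numbers: there is a 2.7-fold higher number from compound 1 to compound 2 (0.44 log units; beyond the scatter), while there is a 6.7-fold lower number from compound 1 to compound 3 (0.83 log units; beyond the scatter), and across the two there is an 18-fold lower number from compound 2 to compound 3 (1.26 log units; beyond the scatter).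

Compound 4 `CCOc1ccc(-c2ccc3ncn(-c4cc(OC)c(OC)c(OC)c4)c3c2)cc1` differs from compound 1 by the following change: 4-ethoxyphenyl in place of 3-fluorophenyl on an aromatic carbon. Among the measured compounds shown here, of the measured steps, only the one from compound 1 to compound 3 touches the same fluoro group, and it gave a modest lower number with a hydroxy entering. For the measured compounds named here, an ethoxy group is not a hydroxy group, it carries no hydrogen-bond donor, and no measured compound carries an ethoxy at all, so that step is only a loose guide. The step to compound 2, which added a second fluoro, points the other way but does not concern the change here. The expectation for compound 4 is therefore a modest step, more likely lower than higher, of about a 1.7-fold lower number from compound 1 to compound 4 (0.22 log units; within the scatter). The estimate for compound 4 is 1400 nM, with a range from 350 nM to 5600 nM.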

Compound 4, half-maximal inhibitory concentration: 1710 nM
For compound 4 the middle estimate is 1.2-fold (0.09 log units) below the measured one; the range from low to high includes it.
By their numbers in this assay, from the lowest: compound 3; then compounds 4 and 1 (each within the scatter of the next); then compound 2.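

In this assay the move to 4-ethoxyphenyl gives a 1.4-fold lower number from compound 1 to compound 4 (0.14 log units; within the scatter) and so, at this position on the shared core, a group of 9 heavy atoms with one hydrogen-bond acceptor reads the same as the 7-atom 3-fluorophenyl group. The hydroxy result is not matched by the ethoxy group: there is a 4.9-fold higher number from compound 3 to compound 4 (0.69 log units; beyond the scatter) and compound 3 remains the lowest of the four, while a 3.8-fold lower number from compound 2 to compound 4 (0.57 log units; beyond the scatter) leaves compound 2 the highest, so that only the 2,5-difluorophenyl and 3-hydroxyphenyl groups move the number beyond the scatter relative to compound 1. Nothing measured alongside these numbers accounts for the differences among the pendant rings.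

Open, as far as these compounds go, is whether the low number of compound 3 depends on the hydroxy group itself or on where it sits on the ring, a question that a 4-hydroxyphenyl and a 3-ethoxyphenyl group would separate. Also open, from the compounds shown here alone, is whether an amine or a carboxylic acid on the pendant ring would read closer to compound 3 or to compound 4, and whether a longer alkoxy chain than ethoxy would still stay within the scatter of compound 1.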